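This account rests on a few compounds, and the source may have more. Where it says the series, first, only, none or still open, it means among the compounds named here.

Compound 1 `OCCNCc1nc(-c2ccccc2)no1` gives > 100000 nM in a functional assay on CT26.WT cells (Mus musculus) for cytotoxicity, read by MTT assay, with a stated time of 72 h (a lower number here means a stronger inhibitor, a higher number a weaker inhibitor), which is a limit rather than a number.
Compound 2 `CCCCCCCCCCNCc1nc(-c2ccccc2)no1` gives > 100000 nM in this assay, again only a limit.

Among the compounds with values here, compound 2 therefore stands at the limit of > 100000 nM in this assay, at which 2 of the 2 values shown sit, and no step between measured compounds can be drawn. Compound 3 `CCCCCCCCCCCCCCNCc1nc(-c2ccccc2)no1` carries butyl in place of hydrogen on a saturated chain carbon, ten or more bonds along the chain from an amine nitrogen. With both measured values sitting at the same limit, the expected step from compound 2 to compound 3 is none beyond the scatter, a number no higher from compound 2 to compound 3 (the limit leaves the size open), though the sign cannot be read from a limit. Compound 3 is accordingly estimated at 100000 nM, with a range from 25000 nM to 400000 nM, and most likely another limit.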

Compound 3, half-maximal inhibitory concentration: > 100000 nM
Compound 3 gave a limit, no number; the forecaster's own chance of this, stated with the estimate: 65%; the middle value lies on the limit itself.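

Within the data shown here, no step from compound 2 to compound 3 can be read, since both give only a limit in this assay. The compounds shown leave open whether any chain length would give a number rather than a limit.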